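This account rests on a few compounds, and the source may have more. Where it says the series, first, only, none or still open, it means among the compounds named here.

Working notes on the series. In a functional assay on MCF7 cells (Homo sapiens) for antiproliferative activity, read by MTT assay, with a stated time of 48 h (on this read-out higher numbers stand for weaker inhibition and lower numbers for stronger inhibition), compound 3 (`COc1ccc(-c2nnc(NC(=O)/C=C/c3ccccc3)s2)cc1`) gives 0.78 ug/mL. This is level with compound 2 (`COc1ccc(/C=C/C(=O)Nc2nnc(-c3ccccc3)s2)cc1`) at 0.83 ug/mL, the two lying within the scatter of each other, while compound 1 (`COc1ccc(-c2nnc(NC(=O)/C=C/c3ccc(C)cc3)s2)cc1`) gives the lowest number at 0.31 ug/mL.

The next structure is compound 4 (`COc1ccc(/C=C/C(=O)Nc2nnc(-c3ccc(OC)cc3)s2)cc1`), and its change from compound 3 is methoxy in place of hydrogen on an aromatic carbon, para to a large group, which reads as phenyl to 4-methoxyphenyl.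

For the measured compounds named here, only one measured step bears on this directly: a 2.5-fold higher number from compound 1 to compound 3 (0.40 log units; beyond the scatter). It is modest, lies beyond the scatter, and removes a methyl from the same ring that gains the methoxy in compound 4. Read in reverse, it shows a lower number with a substituent on that ring than with hydrogen. Going by the values given here, no measured pair tests methoxy against hydrogen on that ring, so the comparison rests on methyl alone and carries limited weight in this assay.

The expected move is therefore modest and towards stronger inhibition, and the estimated step is a 1.6-fold lower number from compound 3 to compound 4 (0.21 log units; within the scatter). For compound 4 the estimated value is 0.48 ug/mL, with an expected range from 0.2 ug/mL to 1.1 ug/mL.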

Compound 4, half-maximal inhibitory concentration: 0.28 ug/mL
For compound 4 the middle estimate is 1.7-fold (0.23 log units) above the measured one; measured number inside the range.
By their numbers in this assay, from the lowest: compounds 4 and 1 (each within the scatter of the next); then compounds 3 and 2 (each within the scatter of the next).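

In this assay methoxy in place of hydrogen is now measured directly on both aromatic rings, para to a large group: a 2.8-fold lower number from compound 3 to compound 4 (0.44 log units; beyond the scatter) and a 3.0-fold lower number from compound 2 to compound 4 (0.47 log units; beyond the scatter), each beyond the scatter, so the lower number does not belong to one ring alone. On the ring that carries methyl in compound 1, methoxy in place of methyl gives a 1.1-fold lower number from compound 1 to compound 4 (0.04 log units; within the scatter), within the scatter, so the two groups cannot be told apart there, while a 2.5-fold higher number from compound 1 to compound 3 (0.40 log units; beyond the scatter) sets methyl apart from hydrogen on that same ring. Nothing measured here gives a reason for these lower numbers.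

On these data alone, what a chloro group, an amine or a carboxylic acid would do at this place remains open, as does whether a longer chain such as ethoxy would keep the lower number. Also open, as far as these compounds go, is whether methyl would match methoxy on the other ring, the one that gains methoxy from compound 2 to compound 4, as the two match on the ring of compound 1.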